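From 4-chlorophenyl to 4-fluorophenyl: one more exchange

This account rests on a few compounds, and the source may have more. Where it says the series, first, only, none or still open, it means among the compounds named here.

In a functional assay on L1210 cells (Mus musculus) for antiproliferative activity, read by cell counting, with a stated time of 48 h (on this read-out lower numbers stand for stronger inhibition and higher numbers for weaker inhibition), three compounds stand measured:
- Compound 1 `C#C[C@@]1(O)[C@@H](CO)O[C@@H](n2cnc3c(-c4ccc(C)cc4)ncnc32)[C@@H]1O` gives 205000 nM
- Compound 2 `C#C[C@@]1(O)[C@@H](CO)O[C@@H](n2cnc3c(-c4ccc(OC)cc4)ncnc32)[C@@H]1O` gives > 250000 nM (a limit of the assay)
- Compound 3 `C#C[C@@]1(O)[C@@H](CO)O[C@@H](n2cnc3c(-c4ccc(Cl)cc4)ncnc32)[C@@H]1O` gives 225000 nM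

Going by the values given here, compound 3 gives 225000 nM as one of only two exact numbers, and the other lies close by, with a 1.1-fold higher number from compound 1 to compound 3 (0.04 log units; within the scatter) on record. Compound 2 gives > 250000 nM and that is a limit of the assay.

The change to compound 4 `C#C[C@@]1(O)[C@@H](CO)O[C@@H](n2cnc3c(-c4ccc(F)cc4)ncnc32)[C@@H]1O` is fluoro in place of chloro on an aromatic carbon, para to a large group, counted as fluoro in place of chloro on an aromatic carbon at that place. Among the compounds with values here, no fluoro compound has been measured yet. The guide is the other exchanges at this place, which gave an at least 1.2-fold higher number from compound 1 to compound 2 (0.08 log units; that floor lies within the scatter) and an at least 1.1-fold lower number from compound 2 to compound 3 (0.04 log units; that floor lies within the scatter) besides the step already named, and these two rest on a limit. Among these three compounds no step leaves the scatter, so none beyond the scatter is expected in this assay here, in either direction. The expected change is a 1.1-fold lower number from compound 3 to compound 4 (0.03 log units; within the scatter) and no more. For compound 4 the estimate is 210000 nM with an expected range from 110000 nM to 250000 nM in this read-out.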

Compound 4, half-maximal inhibitory concentration: > 250000 nM
Compound 4 ended at the assay's limit (the forecaster's own chance of this, stated with the estimate: 25%); middle value at least 1.1-fold (0.07 log units) from the limit.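

In this assay compound 4 joins compound 2 at a limit of the assay, not a number: the limit of > 250000 nM in this assay, at which 2 of the 4 values shown sit. Fluoro in place of chloro gives an at least 1.1-fold higher number from compound 3 to compound 4 (0.04 log units; that floor lies within the scatter), and fluoro in place of methyl gives an at least 1.2-fold higher number from compound 1 to compound 4 (0.08 log units; that floor lies within the scatter), so these floors show no step beyond the scatter, while the step between compound 2 and compound 4 cannot be read. With fluoro added, none of the four groups at this place, methyl, methoxy, chloro and fluoro, has a step printed beyond the scatter, and the exchange of one halogen for the other adds a second limit rather than a sized change.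

On these data alone, how far compound 2 and compound 4 really lie past the limit stays open. Also open, as far as these compounds go, is whether an amine, a carboxylic acid or a longer chain at this place would move the number clearly.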